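Methyl for chloro on the shared core, rat dosing

This account rests on a few compounds, and the source may have more. Where it says the series, first, only, none or still open, it means among the compounds named here.

In a functional assay on the whole organism with Rattus norvegicus as the target (a lower number here means that less compound is needed, a higher number that more compound is needed for the effect), compound 1 `Cc1ccccc1-c1n[nH]c(-c2ccccc2)n1` gives 50 mg/kg. Compound 2 `COc1cccc(-c2n[nH]c(-c3ccc(Cl)cc3C)n2)c1` gives only a limit of the assay in this assay, > 10 mg/kg, and no number. Where compound 2 stands is therefore known only as that limit, (the limit of > 10 mg/kg in this assay, at which 1 of the 2 values shown sits), and no step between compound 1 and compound 2 has been worked out; the two entries show one measured dose and one limit, nothing more.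

Compound 3 `COc1cccc(-c2n[nH]c(-c3ccc(C)cc3C)n2)c1` is not yet measured. It differs from compound 2 by methyl in place of chloro on an aromatic carbon. Among the measured compounds shown here, with no measured step to lean on, the change from compound 2 to compound 3 is expected to move the dose in this assay by no more than the usual scatter, in either direction, giving a step that the limit leaves unreadable from compound 2 to compound 3. Compound 3 is accordingly estimated at 25 mg/kg, within a range from 8 mg/kg to 80 mg/kg.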

Compound 3, dose for half-maximal effect: > 10 mg/kg
Compound 3: no number, only a limit; the forecaster's own chance of this, stated with the estimate: 50%; the middle value lies beyond the limit too.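

No step from compound 2 to compound 3 can be read, because both compounds give only a limit of the assay and no number: the limit of > 10 mg/kg in this assay, at which 2 of the 3 values shown sit.

Going by these compounds, whether methyl in place of chloro on an aromatic carbon moves the dose in this assay at all remains open.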